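The source may report more compounds than this note shows. Statements on the series, on what has been measured and on what is new or still open speak of the compounds shown alone.

Measured in a functional assay on MDA-MB-468 cells (Homo sapiens) for inhibition; a higher number here means a weaker inhibitor, a lower number a stronger inhibitor:
- compound 1 `CCc1cc(N)ccc1-c1nc2ccccc2s1`: < 0.1 nM, a limit of the assay
- compound 2 `Cc1ccc2nc(-c3ccc(N)cc3I)sc2c1`: < 0.1 nM, a limit of the assay

Compound 1 stands at the limit of < 0.1 nM in this assay, at which 2 of the 2 values shown sit. Compound 3 `Nc1ccc(-c2nc3ccccc3s2)c(O)c1` has hydroxy in place of ethyl on an aromatic carbon. Going by the values given here, no measured pair shows what such a swap does, so any expectation here is loose. The value of compound 1, < 0.1 nM, is a limit, so a measurable change in this assay is expected only towards weaker inhibition, and that change may be large. The expected step is an at least 1000-fold higher number from compound 1 to compound 3 (3.00 log units; beyond the scatter). For compound 3 the estimate is 100 nM, with an expected range of 0.1 nM to 10000 nM.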

Compound 3, half-maximal inhibitory concentration: > 10000 nM
Compound 3: only a limit was reported; the forecaster's own chance of this, stated with the estimate: 45%; middle value at least 100-fold (2.00 log units) away from the limit.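

In this assay compound 3 gives > 10000 nM as a limit of the assay. Going by these compounds alone, this is the first sign that the position meta to an amino group does not accept every group: hydroxy in place of ethyl brings an at least 100000-fold higher number from compound 1 to compound 3 (5.00 log units; beyond the scatter) in this series. Both ends of this step are limits of the assay: the limit of > 10000 nM in this assay, at which 1 of the 3 values shown sits.

The compounds shown leave open whether this loss belongs to hydroxy alone or extends to other groups here, such as methoxy, an amine or a longer chain. They also give no cause for the loss.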